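The source may report more compounds than this note shows. Statements on the series, on what has been measured and on what is new or still open speak of the compounds shown alone.

Measured in a functional assay on HL-60 cells (Homo sapiens) for inhibition; on this read-out lower numbers stand for stronger inhibition and higher numbers for weaker inhibition:

Compound 1 `CC1OC(OC2CCCCC2OCCCC(C(=O)O)C(=O)O)C(O)C(O)C1O`: > 5000000 nM
Compound 2 `CC1OC(OC2CCCCC2OCCCCC(C(=O)O)C(=O)O)C(O)C(O)C1O`: > 5000000 nM

Both values are limits of the assay and not numbers. In this assay compound 1 gives > 5000000 nM, a limit. Compound 2 likewise gives > 5000000 nM, again a limit. Between the two sits a step that the two limits leave unreadable from compound 1 to compound 2, so the size of that step cannot be read. Compound 2 therefore stands at the top end of what this assay can report, which is where both measured compounds sit according to the limit of > 5000000 nM in this assay, at which 2 of the 2 values shown sit.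

Compound 3 `CC1OC(OC2CCCCC2OCCCCCC(C(=O)O)C(=O)O)C(O)C(O)C1O` continues the same chain-lengthening: 2,2-dicarboxyethyl in place of dicarboxymethyl on a saturated chain carbon, four bonds along the chain from an oxygen on a saturated carbon. Within the data shown here, the only measured step that bears on this change is the one from compound 1 to compound 2, and its size is unreadable, so no direction or size can be derived from the numbers; the expectation is no readable change, with compound 3 most likely returning another limit in this assay.

Compound 3 is therefore estimated at 5000000 nM, with a range from 2000000 nM to 20000000 nM. The expected step is a number no higher from compound 2 to compound 3 (the limit leaves the size open).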

Compound 3, half-maximal inhibitory concentration: > 5000000 nM
Compound 3: no number, only a limit (the forecaster's own chance of this, stated with the estimate: 90%); the middle value sits exactly at the limit.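

In this assay compound 3 gives > 5000000 nM, which is a limit and not a number, so no step can be read among compound 1, compound 2 and compound 3. The compounds shown leave open whether chain length changes inhibition at all, since none of them yields a number: the limit of > 5000000 nM in this assay, at which 3 of the 3 values shown sit.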